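Methoxy to hydroxy from compound 3 to compound 4

The compounds below may be only part of what the source reports. "The series", "measured", "known", "first", "only" and "open" are said of these compounds alone.

Measured so far in a functional assay on HepG2 cells (Homo sapiens) for inhibition, read by MTT assay, with a stated time of 48 h (a higher number here means a weaker inhibitor, a lower number a stronger inhibitor), on this series:
- compound 1 `COc1cccc(/C=C/C(=O)c2cc(OC)c(OC)c(OC)c2)c1OC` at 11500 nM
- compound 2 `COc1cc(C(=O)/C=C/c2ccc(N(C)C)cc2)cc(OC)c1OC` at 30000 nM
- compound 3 `COc1cc(/C=C/C(=O)c2cc(OC)c(OC)c(OC)c2)ccc1O` at > 100000 nM (a limit only)

Compound 3 has no number: > 100000 nM is a limit of the assay and nothing more. Compound 4 `COc1cc(C(=O)/C=C/c2ccc(O)c(O)c2)cc(OC)c1OC` follows from compound 3 by hydrogen in place of methyl on an oxygen on an aromatic ring with hydrogen in place of methyl on an oxygen on an aromatic ring. Within the data shown here, no measured pair shows this change alone. Compound 1 at 11500 nM and compound 2 at 30000 nM do give numbers in this assay and so a number is also expected here. Expected is an at least 2.5-fold lower number from compound 3 to compound 4 (0.39 log units; beyond the scatter) toward stronger inhibition, of moderate size, though a second limit remains possible. For compound 4 the estimate is 40000 nM with an expected range of 12000 nM to 130000 nM as estimated.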

Compound 4, half-maximal inhibitory concentration: 14900 nM
The estimate for compound 4 lay 2.7-fold (0.43 log units) above the measured number; measured number inside the range.
By their numbers in this assay, from the lowest: compounds 1, 4 and 2 (each within the scatter of the next, the first and the last beyond it). At a limit, above all of these: compound 3.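

In this assay, hydrogen in place of methyl on an oxygen on an aromatic ring goes with an at least 6.7-fold lower number from compound 3 to compound 4 (0.82 log units; beyond the scatter). Among these compounds, this is the first change at this position that can be read. Compound 3 stands at > 100000 nM, a limit and not a number, so the true size of the step stays unknown and only its minimum can be read: the limit of > 100000 nM in this assay, at which 1 of the 4 values shown sits.

Among the compounds shown here, no second pair shows whether methoxy to hydroxy gives a similar step on another compound. On these data alone, what a carboxylic acid or an ethoxy group would do on this ring also stays open.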